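The source may hold more compounds than are shown below. What is called first, only, known or untested is meant among the compounds shown, and "the series" means these compounds.

Measured compounds:
- compound 1 `Cc1ccc(-c2ccnc(C(=O)Nc3ccc(Oc4ccnc5[nH]ccc45)c(F)c3)c2)c(C)c1`: 4350 nM
- compound 2 `CCc1ccc(-c2ccnc(C(=O)Nc3ccc(Oc4ccnc5[nH]ccc45)c(F)c3)c2)cc1`: 3370 nM
- compound 3 `O=C(Nc1ccc(Oc2ccnc3[nH]ccc23)c(F)c1)c1cc(-c2ccc(F)cc2)ccn1`: 1090 nM

All three were run in a functional assay on A549 cells (Homo sapiens) for cytotoxicity, read by MTT assay, with a stated time of 72 h; on this read-out lower numbers stand for stronger inhibition and higher numbers for weaker inhibition. Compound 3 gives the lowest number of the three: the step is a 3.1-fold lower number from compound 2 to compound 3 (0.49 log units; beyond the scatter) and a 4.0-fold lower number from compound 1 to compound 3 (0.60 log units; beyond the scatter), both beyond the scatter, while a 1.3-fold lower number from compound 1 to compound 2 (0.11 log units; within the scatter) stays within it. Compound 3 is therefore the reference point for the next step.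

Compound 4 `O=C(Nc1ccc(Oc2ccnc3[nH]ccc23)c(F)c1)c1cc(-c2ccc(F)cc2F)ccn1` differs from compound 3 by fluoro in place of hydrogen on an aromatic carbon; the change adds one fluorine and nothing else, and the aryl group remains the 4-fluorophenyl, now a 2,4-difluorophenyl. Within the data shown here, none of the measured steps is this change. The steps from compound 1 and compound 2 to compound 3 each replace a larger alkyl-bearing aryl with the 4-fluorophenyl, so they show that a fluoro on this aryl is tolerated, but they say nothing about a second fluoro at the place described. Compound 1, which also carries a group at that place, gives the highest number, yet that group is methyl, not fluoro, so no firm direction follows.

The expectation is therefore a step within the scatter, a 1.1-fold higher number from compound 3 to compound 4 (0.04 log units; within the scatter), from compound 3 to compound 4. For compound 4 the estimate in this assay is 1200 nM, with a range from 500 nM to 3000 nM.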

Compound 4, half-maximal inhibitory concentration: > 10000 nM
Compound 4 gave a limit, no number (the forecaster's own chance of this, stated with the estimate: 5%); middle value at least 8.3-fold (0.92 log units) from the limit.
By their numbers in this assay, from the lowest: compound 3; then compounds 2 and 1 (each within the scatter of the next). At a limit, above all of these: compound 4.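

In this assay compound 4 gives a limit and not a number: the limit of > 10000 nM in this assay, at which 1 of the 4 values shown sits.

A single added fluoro, on an aromatic carbon ortho to a large group and meta to a fluoro group, is the only difference behind an at least 9.1-fold higher number from compound 3 to compound 4 (0.96 log units; beyond the scatter), so the best aryl group of the set is not robust to substitution at this place. The earlier compounds shown here showed only that a 4-fluorophenyl gives a lower number than the two alkyl-bearing aryl groups, whereas the 2,4-difluorophenyl reverses that order, with an at least 2.9-fold higher number from compound 2 to compound 4 (0.47 log units; beyond the scatter) and an at least 2.2-fold higher number from compound 1 to compound 4 (0.36 log units; beyond the scatter); the 2,4-dimethylphenyl, which also carries a group at this place, still gives a measurable number.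

From the compounds shown here alone, how far the true value of compound 4 lies past the limit stays open, and so does the full size of each of these steps. Also open, going by these compounds, is whether the change belongs to fluoro alone or to any group at this place, a question that a methoxy or an amine on the 4-fluorophenyl would address.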